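Adding an ethyl to an amide nitrogen of compound 1

A few compounds are considered here, and "the series" means these few. Any claim that something is new, unique, unknown or untested is made for them only; others in the source may bear on it.

Compound 1 (`O=C(CC(CC(=O)NC1Cc2ccccc2C1)c1ccc(Cl)cc1)NCCN1CCCCC1`) is a weak inhibitor in a functional assay on HeLa cells (Homo sapiens) for inhibition (on this read-out higher numbers stand for weaker inhibition and lower numbers for stronger inhibition), where compound 1 gives 86200 nM. Its close relative compound 2 (`CCN(CC)CCNC(=O)CC(CC(=O)NC1Cc2ccccc2C1)c1ccc(Cl)cc1`) gives 50500 nM, and the two values lie within the scatter of each other. Compound 3 (`O=C(CC(CC(=O)NC1Cc2ccccc2C1)c1ccccc1)NCCN1CCCCC1`) gives > 100000 nM, which is a limit of the assay and not a number. So compound 1 sits close to the top of the range this assay can report.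

Compound 4 (`CCN(C(=O)CC(CC(=O)NCCN1CCCCC1)c1ccc(Cl)cc1)C1Cc2ccccc2C1`) is compound 1 with one change: ethyl in place of hydrogen on an amide-type nitrogen. Neither measured step touches this nitrogen, so the evidence bears on it only indirectly. Diethylamino in place of piperidin-1-yl gives a 1.7-fold lower number from compound 1 to compound 2 (0.23 log units; within the scatter). Hydrogen in place of chloro on an aromatic carbon gives an at least 1.1-fold higher number from compound 1 to compound 3 (0.06 log units; that floor lies within the scatter). Neither shows a change beyond the scatter, but they say nothing directly about substitution at the amide, so the range must stay wide. No clear direction can be drawn from them. The expected step is a 1.1-fold lower number from compound 1 to compound 4 (0.03 log units; within the scatter), an estimate that stays within the scatter. For compound 4 the expected value is 80000 nM, with an estimated range from 30000 nM to 200000 nM.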

Compound 4, half-maximal inhibitory concentration: 20400 nM
Estimate against measurement, compound 4: 3.9-fold (0.59 log units) above, and the stated range ends above it.
By their numbers in this assay, from the lowest: compound 4; then compounds 2 and 1 (each within the scatter of the next). At a limit, above all of these: compound 3.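

In this assay, the amide nitrogen whose other neighbours are a carbonyl carbon and a saturated ring carbon proves to be a place where a small change can be read: ethyl in place of hydrogen gives a 4.2-fold lower number from compound 1 to compound 4 (0.63 log units; beyond the scatter). The amide hydrogen at this position is therefore not required for the inhibition seen in compound 1, and replacing it yields the first step from compound 1 that is printed as clearly beyond the scatter, though it is modest and compound 4 remains a weak inhibitor at 20400 nM. The earlier steps could not show this, since the step to compound 2 lies within the scatter and compound 3 stands at a limit of the assay, not at a number: the limit of > 100000 nM in this assay, at which 1 of the 4 values shown sits.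

The compounds shown leave open whether a methyl, a propyl or a longer chain on this nitrogen would shift the number further, or whether the gain is specific to ethyl. They also leave open whether ethyl on the other amide nitrogen, the one carrying the piperidin-1-yl chain, would act in the same way, and whether the step would hold with diethylamino in place of piperidin-1-yl.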